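The compounds below may be only part of what the source reports. "The series", "measured", "known", "first", "only" and "open" are said of these compounds alone.

Compound 3, with the structure `Cc1nc(C)n(CC(=O)N2CCN(c3sc(C(F)(F)F)nc3-c3cnc(OC(C)C)nc3)C[C@H]2C)n1`, was tested in a functional assay on CHO-K1 cells for antagonist activity at C-X-C chemokine receptor type 3 (Homo sapiens), read by FLIPR, with a stated time of 10 min (on this read-out lower numbers stand for stronger inhibition and higher numbers for weaker inhibition), and gives 3.4 nM. Two close relatives share its core. Compound 1, `CCOc1ncc(-c2nc(C(F)(F)F)sc2N2CCN(C(=O)Cn3ncc4cccnc43)[C@H](C)C2)cn1`, gives 4.1 nM in this assay, and compound 2, `CCOc1ncc(-c2nc(C(F)(F)F)sc2N2CCN(C(=O)Cn3cnc(C(F)(F)F)n3)[C@H](C)C2)cn1`, gives 3.8 nM. All three numbers lie within the usual scatter of one another, so compound 3 cannot be set apart from compound 1 or compound 2 on these data.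

Going by the values given here, the only step measured so far, a 1.1-fold lower number from compound 1 to compound 2 (0.03 log units; within the scatter), swaps the group on the saturated chain carbon bound to the carbonyl carbon, a different place from the change now considered. The new compound 4, `Cc1nc(C)n(CC(=O)N2CCN(c3sc(C(F)(F)F)nc3-c3ccc(C(F)(F)F)nc3)C[C@H]2C)n1`, differs from compound 3 by 6-(trifluoromethyl)pyridin-3-yl in place of 2-isopropoxypyrimidin-5-yl on an aromatic carbon. Among the compounds with values here, no measured pair shows what a swap at this place does, so the expectation rests on the absence of evidence rather than on a trend. A small step, a 2.4-fold higher number from compound 3 to compound 4 (0.37 log units; beyond the scatter), is expected, with a modest loss of inhibition judged more likely than a gain. Compound 4 is therefore estimated at 8 nM, with a range from 2.5 nM to 25 nM.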

Compound 4, half-maximal inhibitory concentration: 4.2 nM
Estimate against measurement, compound 4: 1.9-fold (0.28 log units) above; measured number inside the range.
By their numbers in this assay, from the lowest: compounds 3, 2, 1 and 4 (each within the scatter of the next).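

Going by these compounds alone, on an aromatic carbon, 6-(trifluoromethyl)pyridin-3-yl replaces 2-isopropoxypyrimidin-5-yl with a 1.2-fold higher number from compound 3 to compound 4 (0.09 log units; within the scatter), the first reading of any swap at this place. The two groups match in heavy-atom count but not in kind: fluorine enters, oxygen leaves, and the ring holds 1 hetero atom instead of 2, yet in this pair no effect on the number can be told apart from the scatter. Nothing available explains this result.

Going by these compounds, whether a plain phenyl ring, or a pyridine ring bearing a nitrile, would also stay within the scatter of compound 3 remains open. On these data alone, this swap is also read in a single pair, so its size alongside the side groups of compound 1 and compound 2 is unknown.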